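This account rests on a few compounds, and the source may have more. Where it says the series, first, only, none or still open, it means among the compounds named here.

Compound 1, `CCOC(=O)C1=Cc2ccccc2OC1(OCc1cn(CC(=O)Nc2ccccc2Br)nn1)C(F)(F)F`, belongs to a small set of close analogues that share one core and differ in the group hanging from it. In a functional assay on A549 cells (Homo sapiens) for inhibition, read by MTT assay, with a stated time of 24 h (a lower number here means a stronger inhibitor, a higher number a weaker inhibitor), compound 1 gives > 150000 nM, which is a limit of the assay and not a measured number. Compound 2, `CCOC(=O)C1=Cc2ccccc2OC1(OCc1cc(-c2ccc(Br)cc2)no1)C(F)(F)F`, gives in this assay > 150000 nM, again a limit. Compound 3, `O=C(O)C1=Cc2ccccc2OC1(OCc1cc(-c2ccc([N+](=O)[O-])cc2)no1)C(F)(F)F`, gives in this assay > 150000 nM, a limit as well. Compound 1 thus stands exactly where the rest of the set stands: the limit of > 150000 nM in this assay, at which 3 of the 3 values shown sit. Nothing among the three measured compounds shows a step that could be sized, since every value is a limit.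

Compound 4, `CCOC(=O)C1=Cc2ccccc2OC1(OCc1cn(CC(=O)NC2CCCCC2)nn1)C(F)(F)F`, is the untested member. It differs from compound 1 in one place: cyclohexyl in place of 2-bromophenyl on an amide-type nitrogen. Within the data shown here, since compound 1 sits at the limit with > 150000 nM, the set gives no measured step on which a shift could be read, and the expectation is that the step of a number no higher from compound 1 to compound 4 (the limit leaves the size open) shows no change beyond the scatter. Compound 4 is therefore expected to sit at 150000 nM, with a range from 60000 nM to 300000 nM, and most likely to be reported only as a limit once more.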

Compound 4, half-maximal inhibitory concentration: 9900 nM
Estimate against measurement, compound 4: 15-fold (1.18 log units) above, outside the stated range (below it).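

In this assay, cyclohexyl in place of 2-bromophenyl on an amide-type nitrogen gives an at least 15-fold lower number from compound 1 to compound 4 (1.18 log units; beyond the scatter), which shows that a single change at this position can move a compound of this set off the limit. Among these compounds, for compound 1, the figure of > 150000 nM is a limit of the assay, so the full size of the step stays open, and no other step in the set can be read. Compound 4 is therefore the only compound shown with a measured number, something the earlier compounds could not provide: the limit of > 150000 nM in this assay, at which 3 of the 4 values shown sit.

The compounds shown do not separate the loss of the bromine from the change of the aromatic ring to a non-aromatic one, and a plain phenyl, a cyclopentyl or an open hexyl chain on the same nitrogen would bear on that question. They also leave open whether cyclohexyl on this nitrogen would give a measured number if a carboxylic acid replaced the ethyl ester on the shared core.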